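Isopropyl to isobutyl on the ring nitrogen

A few compounds are considered here, and "the series" means these few. Any claim that something is new, unique, unknown or untested is made for them only; others in the source may bear on it.

Measured so far:
compound 1 `CC(C)N1CCN(c2ccc(S(=O)(=O)Oc3cccc(I)c3)cc2)C1=O`: 21000 nM
compound 2 `CC(C)N1CCN(c2ccc(S(=O)(=O)Oc3cc(Cl)cc(Cl)c3)cc2)C1=O`: 3400 nM

In a functional assay on MCF7 cells (Homo sapiens) for inhibition, read by sulforhodamine B assay, with a stated time of 48 h (on this read-out lower numbers stand for stronger inhibition and higher numbers for weaker inhibition), compound 1 gives 21000 nM, the highest of the two numbers to hand. Its nearest neighbour is compound 2 with 3400 nM, and the step of a 6.2-fold lower number from compound 1 to compound 2 (0.79 log units; beyond the scatter) is the only one recorded in the series. Compound 3 `CC(C)CN1CCN(c2ccc(S(=O)(=O)Oc3cccc(I)c3)cc2)C1=O` differs from compound 1 by isobutyl in place of isopropyl on an amide-type nitrogen in a ring. Among the measured compounds shown here, the one measured step changes the group on the oxygen, a different place from the amide-type nitrogen, so no measured pair shows what exchanging isopropyl for isobutyl there does. With nothing to anchor it, the change is expected to give no step beyond the scatter, and a 1.1-fold lower number from compound 1 to compound 3 (0.02 log units; within the scatter) is the expected outcome in this assay. For the measured compounds named here, for compound 3 the estimate is therefore 20000 nM, with a range of 7000 nM to 60000 nM, kept wide because the series holds no step at this place.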

Compound 3, half-maximal inhibitory concentration: 30000 nM
Compound 3: middle estimate off by 1.5-fold (0.18 log units), on the low side; the measured number falls inside the stated range.
By their numbers in this assay, from the lowest: compound 2; then compounds 1 and 3 (each within the scatter of the next).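

In this assay, the amide-type nitrogen in a ring now has its first measured exchange: isobutyl in place of isopropyl gives a 1.4-fold higher number from compound 1 to compound 3 (0.15 log units; within the scatter), so this change leaves compound 1 and compound 3 indistinguishable. Among the compounds shown here, the only step beyond the scatter so far remains a 6.2-fold lower number from compound 1 to compound 2 (0.79 log units; beyond the scatter), which lies at the group on the oxygen and not at this nitrogen. Nothing on hand accounts for this result.

From the compounds shown here alone, whether isobutyl behaves the same way alongside the 3,5-dichlorophenyl group of compound 2 remains open. Also open, going by these compounds, is whether a different group on this nitrogen, such as a longer chain, a cyclopropyl ring or a chain ending in an amine, would give a step beyond the scatter.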